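Notes on compound 3 and the untested compound 4

A few compounds are considered here, and "the series" means these few. Any claim that something is new, unique, unknown or untested is made for them only; others in the source may bear on it.

Compound 1 `O=C(Nc1cccc(-n2cc(-c3ccncc3)c(-c3ccc(Cl)c(O)c3)n2)c1)Nc1ccc(Cl)c(Cl)c1`: in a functional assay on HCT-15 cells (Homo sapiens) for inhibition, read by sulforhodamine B assay, with a stated time of 48 h (a lower number here means that less compound is tolerated, a higher number that more compound is tolerated), compound 1 gives > 32500 nM, which is a limit.
Compound 2 `COc1cc(-c2nn(-c3cccc(NC(=O)c4ccc(Cl)c(C(F)(F)F)c4)c3)cc2-c2ccncc2)ccc1Cl`: in this assay compound 2 gives > 32500 nM, also a limit.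
Compound 3 `COc1cc(-c2nn(-c3cccc(NC(=O)c4cccc(C(F)(F)F)c4)c3)cc2-c2ccncc2)ccc1Cl`: in this assay compound 3 gives > 50000 nM, again a limit.

Compound 3 therefore stands at a limit, with no number of its own. Two of the three values sit at the limit of > 32500 nM in this assay, at which 2 of the 3 values shown sit, one at the limit of > 50000 nM in this assay, at which 1 of the 3 values shown sits. Among the measured compounds shown here, the single measured step that reaches compound 3, a step that the two limits leave unreadable from compound 2 to compound 3, is hydrogen in place of chloro on an aromatic carbon; both ends are limits, so its size cannot be read.

Compound 4 `COc1cc(-c2nn(-c3cccc(NC(=O)Nc4cccc(C(F)(F)F)c4)c3)cc2-c2ccncc2)ccc1Cl` differs from compound 3 by (3-(trifluoromethyl)phenyl)amino in place of 3-(trifluoromethyl)phenyl on a carbonyl carbon. For the measured compounds named here, no measured step touches this change, and every value so far is a limit, so nothing points to a readable step in either direction. The step that the limit leaves unreadable from compound 3 to compound 4 is expected to stay hidden within the scatter and the limits. Compound 4 is estimated at 60000 nM, with a range of 20000 nM to 200000 nM.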

Compound 4, concentration lethal to 50% of the cells: 50000 nM
For compound 4 the middle estimate is 1.2-fold (0.08 log units) above the measured one, within the range that was stated.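

In this assay, among the compounds shown here, compound 4 gives 50000 nM, the first value that is a number and not a limit, with (3-(trifluoromethyl)phenyl)amino on the carbonyl carbon. The result is a number no higher from compound 3 to compound 4 (the limit leaves the size open) with (3-(trifluoromethyl)phenyl)amino in place of 3-(trifluoromethyl)phenyl on a carbonyl carbon. Compound 3 remains a limit: the limit of > 50000 nM in this assay, at which 1 of the 4 values shown sits.

The step that reaches compound 4 from compound 2 cannot be read, and the change from 3-(trifluoromethyl)phenyl to (3-(trifluoromethyl)phenyl)amino has no size yet at this position.

On these data alone, whether compound 3 and compound 4 differ at all remains open. Also open, as far as these compounds go, is whether another group on this carbonyl carbon, such as cyclohexylamino or a longer alkyl chain, would give a lower number in this assay.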